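This account rests on a few compounds, and the source may have more. Where it says the series, first, only, none or still open, it means among the compounds named here.

Measured so far:
- Compound 1, `COCCOc1cc(C)c(-c2cccc(COc3ccc(S(=O)(=O)CC(=O)O)cc3)c2)c(C)c1`: 126 nM
- Compound 2, `Cc1ccccc1-c1cccc(COc2ccc(S(=O)(=O)CC(=O)O)cc2)c1`: 46.8 nM

Both compounds were tested in a functional assay on CHO cells for agonist activity at Free fatty acid receptor 1 (Homo sapiens), read by FLIPR and calcium flux; a higher number here means that more compound is needed for the effect, a lower number that less compound is needed. Compound 1 gives 126 nM, while compound 2 gives 46.8 nM, a gap that lies beyond the usual scatter of repeated measurements, so compound 2 stands as the lower of the two numbers. For the measured compounds named here, no pair among the measured compounds differs in a single place, so no measured step is available to guide the next change.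

Compound 3, `N#Cc1ccccc1-c1cccc(COc2ccc(S(=O)(=O)CC(=O)O)cc2)c1`, has not yet been measured in this assay. It differs from compound 2 in one spot: cyano in place of methyl on an aromatic carbon. Nothing measured here speaks to a cyano group at this position, so the expectation rests on compound 2 alone. The estimate for compound 3 in this assay is 80 nM, within a range from 25 nM to 300 nM. This means an expected step of a 1.7-fold higher number from compound 2 to compound 3 (0.23 log units; within the scatter), a modest loss that may well stay within the scatter.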

Compound 3, half-maximal effective concentration: 457 nM
Compound 3: middle estimate off by 5.7-fold (0.76 log units), on the low side; the whole stated range lies below it.
By their numbers in this assay, from the lowest: compound 2; then compound 1; then compound 3.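

Changing 2-methylphenyl to 2-cyanophenyl gives, in this assay, a 9.8-fold higher number from compound 2 to compound 3 (0.99 log units; beyond the scatter). For the compounds shown here, this is the first measured step in which only one place changes, and it shows that the choice of group on this aromatic carbon, ortho to a large group, matters: the exchange of methyl for cyano, a change of a single small group, clearly raises the amount of compound needed. Nothing measured here explains the size of this loss.

The compounds shown leave open how other groups at this same carbon would compare, such as a chlorine atom, a methoxy group or an amine. On these data alone, they also leave open how a plain hydrogen there would compare with methyl, so the value of having any group at this carbon remains unknown.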